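A smaller side chain on the shared core

The source may hold more compounds than are shown below. What is called first, only, known or untested is meant among the compounds shown, and "the series" means these compounds.

Measured so far:
compound 1, `O=C(CN(c1nc(Cl)nc2[nH]cnc12)C1CC1)N[C@@H](CC(=O)OCc1ccccc1)C(=O)OCc1ccccc1`: 6.68%
compound 2, `C[C@@H](O)[C@H](NC(=O)CN(c1nc(Cl)nc2[nH]cnc12)C1CC1)C(=O)O`: 24%

In a functional assay on the whole organism (Tail, strain ICR) with Mus musculus as the target, in the tail flick test, with a stated time of 150 min, at a dose of 25 umol/kg by the oral route (a lower number here means a weaker effect, a higher number a stronger effect of the compound at the dose given), compound 2 stands highest of the two numbers. Compound 1 gives 6.68% and lies beyond the scatter below compound 2. Compound 3 `O=C(CN(c1nc(Cl)nc2[nH]cnc12)C1CC1)N[C@@H](CO)C(=O)O` differs from compound 2 only by hydrogen in place of methyl on a saturated chain carbon bound to an oxygen on a saturated carbon and a saturated chain carbon. Within the data shown here, no measured pair shows this change, so its size is unknown; a step of this kind is expected to stay within the scatter, with at most a slight drop. For compound 3 the estimate is 20% (range 8% to 34%), which is expected to mean a step of a number 4 percentage points lower from compound 2 to compound 3 (within the scatter).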

Compound 3, a percentage reported as activity, at one dose (the size of the read-out at that dose, not a potency): 18.8%
For compound 3 the middle estimate is 1.2 percentage points above the measured one, and the stated range covers the measured number.
By their numbers in this assay, from the lowest: compound 1; then compounds 3 and 2 (each within the scatter of the next).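

In this assay, among these compounds, hydrogen in place of methyl on a saturated chain carbon bound to an oxygen gives a number 5.2 percentage points lower from compound 2 to compound 3 (within the scatter) and is the first change here confined to one place. At this dose, the read-out therefore does not separate 1-hydroxyethyl from hydroxymethyl, so the methyl is not required to retain the effect seen with compound 2. Nothing available explains this result. Still open, going by these compounds, is how a longer chain at this carbon would read, or an amine in place of the hydroxyl.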